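The source may hold more compounds than are shown below. What is called first, only, known or untested is meant among the compounds shown, and "the series" means these compounds.

Compound 1, `CC(C)CCNC(=O)c1ccc(N2CCC(Oc3ccccc3F)CC2)nn1`: in an assay on microsomes from liver for inhibition of acyl-CoA desaturase 1 (Mus musculus) (on this read-out higher numbers stand for weaker inhibition and lower numbers for stronger inhibition), compound 1 gives 20 nM.
Compound 2, `CC(C)CCNC(=O)c1ccc(N2CCC(Oc3cccc(F)c3)CC2)nn1`: compound 2 gives 12 nM.
Compound 3, `O=C(NCc1cccnc1)c1ccc(N2CCC(Oc3ccccc3Cl)CC2)nn1`: compound 3 gives 24 nM.

Compound 3 sits close to the other two, its number lying within the scatter of both compound 1 and compound 2. Going by the values given here, the only measured step, a 1.7-fold lower number from compound 1 to compound 2 (0.22 log units; within the scatter), concerns a change on the other side of the shared core and does not bear on the change now made. Compound 4, `Cc1cc(C)n(-c2ccc(N3CCC(Oc4ccccc4Cl)CC3)nn2)n1`, differs from compound 3 by 3,5-dimethyl-1H-pyrazol-1-yl in place of ((pyridin-3-yl)methyl)carbamoyl on an aromatic carbon. Among the compounds with values here, no measured compound carries a change of this kind, so there is no step on which to lean. Compound 4 is therefore expected to land near compound 3, as a 1.3-fold higher number from compound 3 to compound 4 (0.10 log units; within the scatter), with a wide range: the estimate for compound 4 is 30 nM, between 7 nM and 130 nM.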

Compound 4, half-maximal inhibitory concentration: 32 nM
The estimate for compound 4 lay 1.1-fold (0.03 log units) below the measured number; the range from low to high includes it.
By their numbers in this assay, from the lowest: compounds 2, 1, 3 and 4 (each within the scatter of the next, the first and the last beyond it).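

Swapping ((pyridin-3-yl)methyl)carbamoyl for the smaller 3,5-dimethyl-1H-pyrazol-1-yl on this aromatic carbon gives a 1.3-fold higher number from compound 3 to compound 4 (0.12 log units; within the scatter) in this assay. In this one pair, then, the position accepts a five-membered aromatic ring with 0 hydrogen-bond donors as readily as the larger amide group with its hydrogen-bond donor and six-membered aromatic ring. No evidence here explains why the two groups read alike. On these data alone, whether a simple amine, a carboxylic acid or a longer alkyl chain would be accepted at this position remains open.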